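Removing the methyl from the sulfur of compound 2

A few compounds are considered here, and "the series" means these few. Any claim that something is new, unique, unknown or untested is made for them only; others in the source may bear on it.

Compound 1 `CCCc1nc(C)c2c(-c3ccccc3)nnc(SC)n12`: > 48000 nM
Compound 2 `CCCc1nc(C)c2cnnc(SC)n12`: > 48000 nM

Both results in a functional assay for inhibition, with Homo sapiens as the target (a lower number here means a stronger inhibitor, a higher number a weaker inhibitor), are limits of the assay rather than numbers. For compound 1 the result is a limit, > 48000 nM. For compound 2 the result is likewise a limit, > 48000 nM. For the measured compounds named here, the one measured step, a step that the two limits leave unreadable from compound 1 to compound 2, therefore carries no readable size, and compound 2 stands at the limit of this assay, the position shared by both measured values (the limit of > 48000 nM in this assay, at which 2 of the 2 values shown sit).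

Compound 3 `CCCc1nc(C)c2cnnc(S)n12` differs from compound 2 by hydrogen in place of methyl on a sulfur. Going by the values given here, no measured step touches the sulfur substituent, and the single measured step has no readable size, so nothing points to a change in this assay beyond the scatter; the most likely outcome is another limit. The estimate for compound 3 is 60000 nM, with a range from 20000 nM to 200000 nM. The expected step is thus a step that the limit leaves unreadable from compound 2 to compound 3, essentially none.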

Compound 3, half-maximal inhibitory concentration: 10000 nM
Compound 3: the middle estimate sits 6.0-fold (0.78 log units) above what was measured, outside the stated range (below it).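

In this assay, for the compounds shown here, the change from methylsulfanyl to sulfanyl gives the first step that can be read, an at least 4.8-fold lower number from compound 2 to compound 3 (0.68 log units; beyond the scatter). Going by these compounds alone, the only earlier step, hydrogen in place of phenyl on an aromatic carbon, cannot be read, as both of its ends are limits, so the sulfur is the first place on the shared core where a change is seen to bring a result off the limit, and there the smaller substituent, hydrogen, gives the stronger inhibitor. With this, compound 3 is the only one of the three with a value that is a number rather than a limit, and the true size of the step stays bounded on one side only: the limit of > 48000 nM in this assay, at which 2 of the 3 values shown sit.

The compounds shown have only methyl and hydrogen on the sulfur, so they leave open whether an ethyl group or a longer chain there would stay at the limit, and whether an amine or a hydroxyl group in place of the sulfanyl group would keep the gain. They also leave open what a phenyl group on the aromatic carbon would do in the presence of the sulfanyl group, and they do not tell why the change at the sulfur has this effect.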